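The source may hold more compounds than are shown below. What is called first, only, known or untested is meant among the compounds shown, and "the series" means these compounds.

In an ADME assay on CHO cells (Cricetulus griseus) for cytotoxicity, read by MTT assay (on this read-out higher numbers stand for lower toxicity in this test and lower numbers for higher toxicity in this test), compound 1 `NC1CCN(c2nccc3[nH]c(-c4ccc(F)c(F)c4)nc23)CC1` gives 8200 nM and compound 2 `CN1CCN(CC2CCN(c3nccc4[nH]c(-c5ccc(F)c(F)c5)nc34)CC2)CC1` gives 7400 nM, so a 1.1-fold lower number from compound 1 to compound 2 (0.04 log units; within the scatter) leaves compound 2 level with compound 1. Compound 3 `CN1CCN(C(=O)C2CCN(c3nccc4[nH]c(-c5ccc(F)c(F)c5)nc34)CC2)CC1` reports only a limit, > 50000 nM. Compound 4 `CN1CCN(CC2CCN(c3nccc4[nH]c(-c5cccc(OC(F)(F)F)c5)nc34)CC2)CC1` differs from compound 2 on the aromatic side: 3-(trifluoromethoxy)phenyl in place of 3,4-difluorophenyl on an aromatic carbon. The measured steps all sit on a saturated ring carbon, including an at least 6.7-fold higher number from compound 2 to compound 3 (0.82 log units; beyond the scatter), so none of them tests a change on this aromatic carbon. Among the compounds with values here, with no direct precedent, no step beyond the scatter is expected in this assay. The estimated step is a 1.1-fold lower number from compound 2 to compound 4 (0.06 log units; within the scatter). For compound 4 the expected value is 6500 nM, with an estimated range of 2500 nM to 16000 nM.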

Compound 4, half-maximal cytotoxic concentration: 950 nM
Compound 4: middle estimate off by 6.8-fold (0.84 log units), on the high side; measured number outside the range, below it.
By their numbers in this assay, from the lowest: compound 4; then compounds 2 and 1 (each within the scatter of the next). At a limit, above all of these: compound 3.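

In this assay, replacing 3,4-difluorophenyl with 3-(trifluoromethoxy)phenyl on the aromatic carbon gives a 7.8-fold lower number from compound 2 to compound 4 (0.89 log units; beyond the scatter). Within the data shown here, the earlier steps all lay on a saturated ring carbon, so this is the first sign that the number also responds to a change at this aromatic place. Nothing measured here accounts for the step. Still open, on these data alone, is whether 3-(trifluoromethoxy)phenyl would lower the number in the same way on compound 1 or compound 3. Also open, as far as these compounds go, is how an unsubstituted phenyl or a 3-methoxyphenyl would read at this carbon.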